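A few compounds are considered here, and "the series" means these few. Any claim that something is new, unique, unknown or untested is made for them only; others in the source may bear on it.

Measured so far in a toxicity assay on microsomes from liver (Homo sapiens) for metabolic stability, read by LC-MS, using NADPH, tested at 1 uM (on this read-out higher numbers stand for fast clearance and lower numbers for slow clearance), are two compounds.
- compound 1 `Cc1nc(C)n(CC(=O)N2CCN(c3sc(C(F)(F)F)nc3-c3cnc(OC4CCC4)nc3)C[C@H]2C)n1` with 51 mL.min-1.g-1
- compound 2 `CCCc1ncc(-c2nc(C(F)(F)F)sc2N2CCN(C(=O)Cn3nc(C)nc3C)[C@H](C)C2)cn1` with 80 mL.min-1.g-1

For the measured compounds named here, compound 2 stands level with the only other measured number, since the step of a 1.6-fold higher number from compound 1 to compound 2 (0.20 log units; within the scatter) lies within the scatter. The next structure is compound 3 `CCOc1ccc(-c2nc(C(F)(F)F)sc2N2CCN(C(=O)Cn3nc(C)nc3C)[C@H](C)C2)cn1`, which carries 6-ethoxypyridin-3-yl in place of 2-propylpyrimidin-5-yl on an aromatic carbon of the five-membered aromatic ring with 1 nitrogen and 1 sulfur (see 6-ethoxypyridin-3-yl in place of 2-propylpyrimidin-5-yl on an aromatic carbon for the count). Going by the values given here, one measured step bears on this change, the step of a 1.6-fold higher number from compound 1 to compound 2 (0.20 log units; within the scatter), which put propyl in place of cyclobutyloxy on an aromatic carbon and stayed within the scatter. Among the compounds with values here, that step touches only part of the present exchange, and no measured step covers the change in the ring hetero atoms. On this thin evidence, no shift beyond the scatter is expected in this assay, and the expected step is a 1.2-fold lower number from compound 2 to compound 3 (0.07 log units; within the scatter) with a wide margin. In this assay the estimate for compound 3 is 68 mL.min-1.g-1 (expected range 34 mL.min-1.g-1 to 130 mL.min-1.g-1).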

Compound 3, intrinsic clearance in microsomes: 66 mL.min-1.g-1
The estimate for compound 3 lay 1.0-fold (0.01 log units) above the measured number; the measured number falls inside the stated range.
By their numbers in this assay, from the lowest: compounds 1, 3 and 2 (each within the scatter of the next).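

On the aromatic carbon next to the ring nitrogen, one six-membered aromatic ring with 1 hetero atom now stands in place of one with 2 hetero atoms, and this assay shows a 1.2-fold lower number from compound 2 to compound 3 (0.08 log units; within the scatter). Against the 2-(cyclobutyloxy)pyrimidin-5-yl of compound 1, 6-ethoxypyridin-3-yl gives a 1.3-fold higher number from compound 1 to compound 3 (0.11 log units; within the scatter), so this position has now been varied in the ring hetero atoms as well as in the chain, and neither comparison leaves the scatter. No evidence at hand accounts for this result.

Open, as far as these compounds go, is whether any group at this position can move the read-out beyond the scatter, for instance an amine or a carboxylic acid on the six-membered ring in place of the ethoxy or propyl chain. From the compounds shown here alone, the three compounds also share the rest of their structure, so what a nitrile in place of the trifluoromethyl group would do to the clearance, alone or together with a change at this position, remains unknown.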